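This account rests on a few compounds, and the source may have more. Where it says the series, first, only, none or still open, it means among the compounds named here.

Compound 1 `C=C1C(=O)O[C@]2(C)CC[C@@H]1C[C@H](O)[C@@]1(C)CC[C@H](O1)[C@](C)(O)CC[C@H]2OC(C)=O` was examined in a functional assay on Doay cells (Homo sapiens) for cytotoxicity, read by MTT assay; on this read-out lower numbers stand for an effect already at smaller amounts and higher numbers for an effect only at larger amounts of compound. In this assay compound 1 reaches only the limit < 20 ug/mL. Compound 2 `C=C1C(=O)O[C@]2(C)CC[C@@H]1C[C@H](OC(C)=O)[C@@]1(C)CC[C@H](O1)[C@](C)(O)CC[C@H]2OC(C)=O` differs from it by acetyl in place of hydrogen on an oxygen on a saturated carbon. In this assay compound 2 likewise gives only the limit < 20 ug/mL. The step that the two limits leave unreadable from compound 1 to compound 2 stays unsized because of the limit of < 20 ug/mL in this assay, at which 3 of the 3 values shown sit. Compound 3 `C=C1C(=O)O[C@]2(C)CC[C@@H]1C[C@H](O)[C@@]1(C)CC[C@H](O1)C(=C)CC[C@H]2OC(C)=O` stands on a second core; the difference between the two cores is not broken down here. In this assay compound 3 also returns only the limit < 20 ug/mL. Compound 4 `C=C1C(=O)O[C@]2(C)CC[C@@H]1C[C@H](OC(C)=O)[C@@]1(C)CC[C@H](O1)C(=C)CC[C@H]2OC(C)=O` has not yet been measured and differs from compound 3 by acetyl in place of hydrogen on an oxygen on a saturated carbon, the same change as between the first pair. Because the step that the two limits leave unreadable from compound 1 to compound 2 could not be read, compound 4 is expected to show a step that the limit leaves unreadable from compound 3 to compound 4. Compound 4 is therefore estimated at 8 ug/mL, most probably again as a limit only.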

Compound 4, concentration for half-maximal effect: < 20 ug/mL
Compound 4: no number, only a limit (the forecaster's own chance of this, stated with the estimate: 70%); the middle value lies beyond the limit too.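

For the compounds shown here, compound 4, like compound 3, gives only a limit, so no step between them can be read: the limit of < 20 ug/mL in this assay, at which 4 of the 4 values shown sit. The compounds shown leave open what actual value each would reach and whether acetyl in place of hydrogen makes any difference.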